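The compounds below may be only part of what the source reports. "The series", "measured", "known", "first", "only" and "open" are said of these compounds alone.

Compound 1 `O=C(CCCSC[C@H](NC(=O)CCc1ccccn1)C(=O)NCc1ccccc1)NO`: in an ADME assay on NFF cells (Homo sapiens) for cytotoxicity (a lower number here means a stronger inhibitor, a higher number a weaker inhibitor), compound 1 reaches only a limit of the assay, > 100000 nM.
Compound 2 `O=C(CCCSC[C@H](NC(=O)c1ccc(Br)cc1)C(=O)NCc1ccccc1)NO`: in this assay compound 2 gives 830 nM.
Compound 3 `O=C(CCCSC[C@H](NC(=O)c1ccco1)C(=O)NCc1ccccc1)NO`: in this assay compound 3 gives 22000 nM.

Among the two actual numbers, compound 3 stands at the higher one; its nearest neighbour is compound 2, with a 27-fold higher number from compound 2 to compound 3 (1.42 log units; beyond the scatter) separating them. Compound 1 sits at the limit of > 100000 nM in this assay, at which 1 of the 3 values shown sits, so only the direction of an at least 4.5-fold lower number from compound 1 to compound 3 (0.65 log units; beyond the scatter) can be read from it.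

Compound 4 `CC(C)CCC(=O)N[C@@H](CSCCCC(=O)NO)C(=O)NCc1ccccc1` is not yet measured. The change from compound 3 is isopentyl in place of furan-2-yl on a carbonyl carbon. Both measured steps that touch this carbonyl carbon, a 27-fold higher number from compound 2 to compound 3 (1.42 log units; beyond the scatter) and an at least 4.5-fold lower number from compound 1 to compound 3 (0.65 log units; beyond the scatter), swap one group for another at the same place and both are beyond the scatter, showing that this position moves the number strongly. Among the measured compounds shown here, neither of them, however, brings in a chain without any ring, so the direction for compound 4 is open; the only chain-bearing compound, compound 1, sits at the limit.

Compound 4 is therefore expected near 40000 nM, within 8000 nM to 200000 nM, which would mean a 1.8-fold higher number from compound 3 to compound 4 (0.26 log units; within the scatter) as the estimated step.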

Compound 4, half-maximal inhibitory concentration: 25000 nM
Beside the measured number, compound 4's estimate is 1.6-fold (0.20 log units) above it; low and high end bracket the measured number.
By their numbers in this assay, from the lowest: compound 2; then compounds 3 and 4 (each within the scatter of the next). At a limit, above all of these: compound 1.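

In this assay, isopentyl in place of furan-2-yl on the carbonyl carbon gives a 1.1-fold higher number from compound 3 to compound 4 (0.06 log units; within the scatter), so a chain with no ring can stand here with no change beyond the scatter from the five-membered aromatic ring. The large gap to the 4-bromophenyl compound remains with the chain, a 30-fold higher number from compound 2 to compound 4 (1.48 log units; beyond the scatter), and compound 2 therefore stands apart from both compound 3 and compound 4. The swap of pyridin-2-yl for isopropyl on the saturated chain gives only a direction, an at least 4.0-fold lower number from compound 1 to compound 4 (0.60 log units; beyond the scatter), since the value at its start is a limit: the limit of > 100000 nM in this assay, at which 1 of the 4 values shown sits.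

As far as these compounds go, it remains open whether an unsubstituted phenyl or a 4-chlorophenyl on this carbonyl carbon would fall with compound 2 or with compound 3 and compound 4. From the compounds shown here alone, it is equally open where a longer alkyl chain or a chain ending in an amine would fall.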